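This account rests on a few compounds, and the source may have more. Where it says the series, first, only, none or still open, it means among the compounds named here.

In a functional assay on the whole organism for antagonist activity, with Rattus norvegicus as the target (on this read-out lower numbers stand for an effect already at smaller amounts and higher numbers for an effect only at larger amounts of compound), compound 1 `N#Cc1nc2ccccc2nc1N1CCNCC1` gives 0.000027 mg/kg and compound 2 `CCN1CCN(c2nc3ccccc3nc2C#N)CC1` gives 0.000015 mg/kg, so the two numbers lie within the scatter of each other. Compound 3 `CCCN1CCN(c2nc3ccccc3nc2C#N)CC1` differs from compound 2 as follows: methyl in place of hydrogen on a saturated chain carbon, two bonds along the chain from an amine nitrogen in a ring. This is methyl in place of hydrogen on a saturated chain carbon, two bonds along the chain from an amine nitrogen in a ring, or ethyl to propyl when cut one bond further out. Among the compounds with values here, the only measured step bearing on this change is a 1.8-fold lower number from compound 1 to compound 2 (0.26 log units; within the scatter), which places ethyl on the amine nitrogen in a ring and stays within the scatter. Within the data shown here, no measured step covers the chain carbon itself, so no step beyond the scatter is expected in this assay, and no direction is favoured. The expected step is a 1.2-fold higher number from compound 2 to compound 3 (0.08 log units; within the scatter). For compound 3 the estimated value is 0.000018 mg/kg, with an expected range of 0.000006 mg/kg to 0.00006 mg/kg.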

Compound 3, dose for 50% inhibition: 0.00038 mg/kg
Compound 3: the middle estimate sits 21-fold (1.32 log units) below what was measured; measured number above the stated range.
By their numbers in this assay, from the lowest: compounds 2 and 1 (each within the scatter of the next); then compound 3.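

In this assay, the change from ethyl to propyl on the amine nitrogen in a ring is far from neutral: a 25-fold higher number from compound 2 to compound 3 (1.40 log units; beyond the scatter) follows from methyl in place of hydrogen on a saturated chain carbon, two bonds along the chain from that nitrogen. Propyl in place of hydrogen on the same nitrogen also gives a 14-fold higher number from compound 1 to compound 3 (1.15 log units; beyond the scatter), whereas ethyl in place of hydrogen stayed within the scatter, so among these compounds the read-out at this nitrogen is flat from hydrogen to ethyl and shifts sharply only at propyl. Nothing available explains this jump.

Going by these compounds, whether the number keeps rising with a longer chain such as butyl remains open. On these data alone, it is equally open whether isopropyl or cyclopropyl on the same nitrogen would behave like ethyl or like propyl.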